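Thiophen-2-yl for pyridin-4-yl on compound 3

A few compounds are considered here, and "the series" means these few. Any claim that something is new, unique, unknown or untested is made for them only; others in the source may bear on it.

Among the measured compounds shown here, in a functional assay on PC-3 cells (Homo sapiens) for antiproliferative activity, read by MTT assay, with a stated time of 48 h (a lower number here means a stronger inhibitor, a higher number a weaker inhibitor), compound 3 `O=C(CCCCCCC(=O)Nc1nnc(-c2ccncc2)s1)NO` gives 7750 nM, the only actual number so far. Compound 1 `O=C(CCCCCC(=O)Nc1nnc(-c2ccncc2)s1)NO` reads > 60000 nM, which is a limit of the assay. Compound 2 `O=C(CCCCCC(=O)Nc1nnc(-c2cccs2)s1)NO` reads > 60000 nM, also a limit. Compound 4 `O=C(CCCCCCC(=O)Nc1nnc(-c2cccs2)s1)NO` keeps the chain of compound 3 and changes one group: thiophen-2-yl in place of pyridin-4-yl on an aromatic carbon. The same swap links another pair, a step that the two limits leave unreadable from compound 1 to compound 2, so it offers no size to carry over. The other measured step, an at least 7.7-fold lower number from compound 1 to compound 3 (0.88 log units; beyond the scatter), alters the chain rather than this group. With no readable size for the swap, no step beyond the scatter is expected in this assay, and the expected step is a 1.0-fold higher number from compound 3 to compound 4 (0.01 log units; within the scatter). For compound 4 the estimated value is 8000 nM, with an expected range of 2500 nM to 30000 nM.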

Compound 4, half-maximal inhibitory concentration: 3600 nM
Compound 4: middle estimate off by 2.2-fold (0.35 log units), on the high side; low and high end bracket the measured number.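

In this assay, thiophen-2-yl in place of pyridin-4-yl now has a readable size on the chain of compound 3 (a 2.2-fold lower number from compound 3 to compound 4 (0.33 log units; beyond the scatter)), a modest gain. The same swap from compound 1 to compound 2 cannot be read, as both values are limits. (Hydroxycarbamoyl)methyl in place of hydroxycarbamoyl also lowers the number with thiophen-2-yl on the ring (an at least 16-fold lower number from compound 2 to compound 4 (1.22 log units; beyond the scatter)), so that chain change is not tied to pyridin-4-yl. As far as these compounds go, how far the chain change differs between the two ring groups stays open. So does how a phenyl or furan-2-yl group, or a still longer chain, would read here.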